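Replacing the indolecarbonyl amide with a tosyl sulfonamide

The source may report more compounds than this note shows. Statements on the series, on what has been measured and on what is new or still open speak of the compounds shown alone.

The series keeps a tetradecyl amide and a threonine-derived core and varies only the acyl group on the amine nitrogen. Compound 1 `CCCCCCCCCCCCCCNC(=O)[C@@H](NC(=O)c1ccccc1)[C@@H](C)O` gives 200000 nM in a functional assay on SW-620 cells (Homo sapiens) for cytotoxicity, read by MTT assay, with a stated time of 48 h; a lower number here means a stronger inhibitor, a higher number a weaker inhibitor. Compound 2 `CCCCCCCCCCCCCCNC(=O)[C@@H](NC(=O)c1cccs1)[C@@H](C)O` gives 78400 nM in this assay. Compound 3 `CCCCCCCCCCCCCCNC(=O)[C@@H](NC(=O)c1cc2ccccc2[nH]1)[C@@H](C)O` gives 15200 nM in this assay and thus holds the lowest number of the three. For the measured compounds named here, the steps are a 2.6-fold lower number from compound 1 to compound 2 (0.41 log units; beyond the scatter), a 5.2-fold lower number from compound 2 to compound 3 (0.71 log units; beyond the scatter) and a 13-fold lower number from compound 1 to compound 3 (1.12 log units; beyond the scatter): the larger the aromatic group on the carbonyl carbon, the lower the number, with no compound going against this among the three.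

Compound 4 `CCCCCCCCCCCCCCNC(=O)[C@@H](NS(=O)(=O)c1ccc(C)cc1)[C@@H](C)O` differs from compound 3 by (4-methylphenyl)sulfonyl in place of (1H-indol-2-yl)carbonyl on an amine nitrogen. Going by the values given here, no measured step covers a sulfonyl in place of a carbonyl, so the only guide is the size of the aryl group. The entering group is a single six-membered carbon ring with a methyl, closer in that respect to compound 1 than to compound 3, and the measured steps all went toward lower numbers as the ring system grew. The expected step is therefore a 6.6-fold higher number from compound 3 to compound 4 (0.82 log units; beyond the scatter), toward a higher number, with wide uncertainty because of the change in the linking group. Compound 4 is estimated at 100000 nM in this assay, with a range from 30000 nM to 300000 nM.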

Compound 4, half-maximal inhibitory concentration: 15200 nM
For compound 4 the middle estimate is 6.6-fold (0.82 log units) above the measured one; measured number below the stated range.
By their numbers in this assay, from the lowest: compounds 3 and 4 (each within the scatter of the next); then compound 2; then compound 1.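

Working notes on the acyl position: in this assay the exchange on this amine nitrogen gives no change at the digits printed from compound 3 to compound 4 (within the scatter) as its result, so a (4-methylphenyl)sulfonyl group here serves on a par with (1H-indol-2-yl)carbonyl despite carrying one six-membered aromatic ring instead of the two rings of the leaving group. The sulfonamide keeps the whole distance to the other two compounds, with a 5.2-fold lower number from compound 2 to compound 4 (0.71 log units; beyond the scatter) on one side and a 13-fold lower number from compound 1 to compound 4 (1.12 log units; beyond the scatter) on the other, and compound 4 therefore goes against the trend read from compounds 1 to 3, where a larger aromatic group went with a lower number. No measurement at hand offers a reason for this result.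

The compounds shown leave open whether the sulfonyl link or the methyl on the ring carries the difference from compound 1, a question that a 4-methylbenzoyl group and an unsubstituted phenylsulfonyl group on the same nitrogen would separate. Also open, on these data alone, is whether compounds 3 and 4 would stay level with a shorter chain in place of tetradecyl, or with a carboxylic acid on the aromatic ring.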